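This account rests on a few compounds, and the source may have more. Where it says the series, first, only, none or still open, it means among the compounds named here.

Of the compounds shown here, three built on one shared core have been tested in a functional assay on HCT-15 cells (Homo sapiens) for inhibition, read by sulforhodamine B assay; on this read-out lower numbers stand for stronger inhibition of growth and higher numbers for weaker inhibition of growth. Compound 1 `O=C(CCC1=CCN(CCCc2ccc(Cl)cc2)C1=O)NO` gives 5100 nM, compound 2 `O=C(CCC1=CCN(Cc2ccc(F)cc2)C1=O)NO` gives 4070 nM, and compound 3 `Cc1ccc(CCCCN2CC=C(CCC(=O)NO)C2=O)cc1` gives 8540 nM, the highest of the three numbers; its gap to compound 1 lies within the usual scatter, while its gap to compound 2 lies beyond it. Compound 4 `O=C(CCC1=CCN(CCCCc2ccc(Cl)cc2)C1=O)NO` has not yet been measured. It differs from compound 3 in one place: chloro in place of methyl on an aromatic carbon. For the measured compounds named here, no measured pair shows this change on its own. Since compound 1, which carries the chloro group, gives 5100 nM and compound 3 gives 8540 nM, only a modest step is expected, a 1.4-fold lower number from compound 3 to compound 4 (0.15 log units; within the scatter), within the scatter. Compound 4 is therefore estimated at 6000 nM, in a range from 2500 nM to 15000 nM.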

Compound 4, concentration for 50% growth inhibition: 8540 nM
The estimate for compound 4 lay 1.4-fold (0.15 log units) below the measured number; the range from low to high includes it.
By their numbers in this assay, from the lowest: compounds 2, 1, 3 and 4 (each within the scatter of the next, the first and the last beyond it).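

In this assay chloro in place of methyl on an aromatic carbon, para to a large group, brings no change at the digits printed from compound 3 to compound 4 (within the scatter) and so leaves the two groups indistinguishable at this position on this read-out. For the compounds shown here, this is the first pair to show the change on its own, and it is a single pair. Nothing measured here bears on why the two groups read alike. As far as these compounds go, whether an amine, a carboxylic acid or a methoxy group at this position would shift the number stays open. So does whether the same change would read alike on a shorter chain.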